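The source may hold more compounds than are shown below. What is called first, only, known or untested is meant among the compounds shown, and "the series" means these compounds.

Compound 1, `CC(=O)NCc1cccc(Cn2nc(NS(=O)(=O)c3ccc(Cl)s3)c3c(F)cccc32)c1`: 79.4 nM
Compound 2, `CC(=O)NCc1cccc(Cn2nc(NS(=O)(=O)c3ccc(Cl)s3)c3c(C(C)=O)cccc32)c1`: 100 nM
Compound 3, `CC(=O)NCc1cccc(Cn2nc(NS(=O)(=O)c3ccc(Cl)s3)c3c(C(C)O)cccc32)c1`: 20 nM

In a functional assay on CHO cells for antagonist activity at C-C chemokine receptor type 4 (Homo sapiens), read by GTPgammaS binding (on this read-out lower numbers stand for stronger inhibition and higher numbers for weaker inhibition), compound 1 gives 79.4 nM, the second highest of the three numbers. Its nearest neighbour is reached by a 1.3-fold higher number from compound 1 to compound 2 (0.10 log units; within the scatter); its furthest by a 4.0-fold lower number from compound 1 to compound 3 (0.60 log units; beyond the scatter).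

Compound 4, `CC(=O)NCc1cccc(Cn2nc(NS(=O)(=O)c3ccc(Cl)s3)c3c(C(F)F)cccc32)c1`, differs from compound 1 by difluoromethyl in place of fluoro on an aromatic carbon. Two measured steps change the same aromatic carbon: a 1.3-fold higher number from compound 1 to compound 2 (0.10 log units; within the scatter), within the scatter, and a 4.0-fold lower number from compound 1 to compound 3 (0.60 log units; beyond the scatter), beyond it. Of these, the entering difluoromethyl resembles the acetyl case more closely, since it brings no hydrogen-bond donors and no hydrogen-bond acceptors, whereas the gain in compound 3 came with a 1-hydroxyethyl group. The expected change is therefore a 1.3-fold lower number from compound 1 to compound 4 (0.10 log units; within the scatter), no step beyond the scatter. Compound 4 is estimated at 63 nM, in the range 25 nM to 160 nM.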

Compound 4, half-maximal inhibitory concentration: 100 nM
Estimate against measurement, compound 4: 1.6-fold (0.20 log units) below; low and high end bracket the measured number.
By their numbers in this assay, from the lowest: compound 3; then compounds 1, 2 and 4 (each within the scatter of the next).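

In this assay, difluoromethyl cannot be told apart from fluoro (a 1.3-fold higher number from compound 1 to compound 4 (0.10 log units; within the scatter)) or from acetyl (no change at the digits printed from compound 2 to compound 4 (within the scatter)), so three different groups on this aromatic carbon now give matching numbers. Only the 1-hydroxyethyl group of compound 3 stands apart (a 5.0-fold higher number from compound 3 to compound 4 (0.70 log units; beyond the scatter)). Nothing available here explains that gap.

From the compounds shown here alone, whether the hydroxyl is what matters remains open. A hydroxymethyl, methoxymethyl or aminomethyl group on the same carbon would help to test this.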